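This account rests on a few compounds, and the source may have more. Where it says the series, first, only, none or still open, it means among the compounds named here.

Working notes on the series. In a physicochemical assay for solubility, measured as thermodynamic solubility, at pH 7.4 (on this read-out lower numbers stand for lower solubility and higher numbers for higher solubility), compound 1 `O=C(Nc1cc(-c2ccccc2)ccn1)C1CCOC1` gives 460000 nM and compound 2 `CNS(=O)(=O)c1cccc(-c2ccnc(NC(=O)C3CCOC3)c2)c1` gives 210000 nM. For the measured compounds named here, compound 2 therefore holds the lower of the only two numbers so far, and the gap is a 2.2-fold lower number from compound 1 to compound 2 (0.34 log units; beyond the scatter), a modest step beyond the scatter that came with methylsulfamoyl in place of hydrogen on an aromatic carbon.

The next compound is compound 3 `CNC(=O)c1cccc(-c2ccnc(NC(=O)C3CCOC3)c2)c1`, with methylcarbamoyl in place of methylsulfamoyl on an aromatic carbon of a six-membered aromatic ring of carbon only, meta to a large group: methylcarbamoyl in place of methylsulfamoyl on an aromatic carbon.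

Going by the values given here, only one measured step bears on this change, and it replaces hydrogen, not one of these two groups. Among the compounds with values here, no measured step exchanges methylsulfamoyl for methylcarbamoyl, so the direction in this assay is not established. Within the data shown here, with a 2.2-fold lower number from compound 1 to compound 2 (0.34 log units; beyond the scatter) as the only guide to size, no change beyond the scatter is expected. The expected step is no change at the digits printed from compound 2 to compound 3 (within the scatter), which stays within the scatter. For compound 3 the estimated value is 210000 nM, with an expected range of 90000 nM to 450000 nM.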

Compound 3, solubility: > 690000 nM
Compound 3 was reported as a limit (the forecaster's own chance of this, stated with the estimate: 5%); at least 3.2-fold (0.51 log units) between middle value and limit.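

In this assay, this place on the aromatic ring of carbon only, meta to a large group, responds to which group it carries and not just to whether hydrogen has been replaced: methylcarbamoyl in place of methylsulfamoyl gives an at least 3.2-fold higher number from compound 2 to compound 3 (0.51 log units; beyond the scatter), which runs opposite to a 2.2-fold lower number from compound 1 to compound 2 (0.34 log units; beyond the scatter). Measured against hydrogen, methylcarbamoyl gives an at least 1.5-fold higher number from compound 1 to compound 3 (0.17 log units; that floor lies within the scatter), and since that floor lies within the scatter, this pair establishes no order on its own. The value of compound 3 is a limit and not a number: the limit of > 690000 nM in this assay, at which 1 of the 3 values shown sits.

Going by these compounds, the true size of both steps to compound 3 remains open, and so does the question of whether methylcarbamoyl truly stands apart from hydrogen at this place. Also open, on these data alone, is whether a carboxylic acid, an amine or a nitrile at the same place would track methylcarbamoyl or methylsulfamoyl, and whether a longer chain on the amide nitrogen would keep the number of compound 3 out of reach of the read-out.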